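Stereoisomer series: estimate for the fourth configuration

The compounds below may be only part of what the source reports. "The series", "measured", "known", "first", "only" and "open" are said of these compounds alone.

Four stereoisomers of one acyclic-enone carbinol share every atom and bond and differ only in configuration as drawn. In an ADME assay on HT-29 cells (Homo sapiens) for cytotoxicity (a higher number here means a weaker inhibitor, a lower number a stronger inhibitor), compound 1 `CC(=O)/C=C/[C@@]1(O)[C@H](C)C[C@H](O)CC1(C)C` gives 43 ug/mL, compound 2 `CC(=O)/C=C/[C@@]1(O)[C@@H](C)C[C@@H](O)CC1(C)C` gives 17 ug/mL, and compound 3 `CC(=O)/C=C/[C@]1(O)[C@@H](C)C[C@@H](O)CC1(C)C` gives 8.1 ug/mL, the lowest of the three numbers. For the measured compounds named here, the measured steps were all modest: a 2.5-fold lower number from compound 1 to compound 2 (0.40 log units; beyond the scatter), a 5.3-fold lower number from compound 1 to compound 3 (0.72 log units; beyond the scatter) and a 2.1-fold lower number from compound 2 to compound 3 (0.32 log units; beyond the scatter); in each case the only change was the configuration the fact that compounds 1 and 2 differ only in the configuration as drawn the fact that compounds 1 and 3 differ only in the configuration as drawn (the fact that compounds 2 and 3 differ only in the configuration as drawn).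

Compound 4 `CC(=O)/C=C/[C@]1(O)[C@H](C)C[C@H](O)CC1(C)C` is not yet measured. It differs from compound 3 as follows: the two compounds have the same atoms and bonds and differ only in configuration as drawn: 2 of 4 stereo elements differ; a stereocentre at a saturated ring carbon is drawn S in compound 3 and R in compound 4; a stereocentre at a saturated ring carbon is drawn R in compound 3 and S in compound 4. The same ring stereocentres separate compound 1 from compound 2, where a 2.5-fold lower number from compound 1 to compound 2 (0.40 log units; beyond the scatter) was seen, so the step bearing most directly on compound 4 runs in the opposite sense here. A higher number for compound 4 than for compound 3 is therefore expected, by roughly the size of that earlier step, consistent with the spread of the three known values. The estimated step is a 2.5-fold higher number from compound 3 to compound 4 (0.39 log units; beyond the scatter). For compound 4 the expected value in this assay is 20 ug/mL, with a range from 11 ug/mL to 36 ug/mL.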

Compound 4, half-maximal inhibitory concentration: 8.5 ug/mL
Compound 4: the middle estimate sits 2.4-fold (0.37 log units) above what was measured, outside the stated range (below it).
By their numbers in this assay, from the lowest: compounds 3, 4 and 2 (each within the scatter of the next, the first and the last beyond it); then compound 1.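

The two ring stereocentres that gave a 2.5-fold lower number from compound 1 to compound 2 (0.40 log units; beyond the scatter) have no readable effect in the other setting: a 1.0-fold higher number from compound 3 to compound 4 (0.02 log units; within the scatter), so what they do depends on the rest of the configuration. A single ring stereocentre separates the two ends of this pattern, with a 5.1-fold lower number from compound 1 to compound 4 (0.70 log units; beyond the scatter), and compound 1 is now the weakest of the four, its steps to all three others lying beyond the scatter. Compounds 2 and 4 do not separate, with a 2.0-fold lower number from compound 2 to compound 4 (0.30 log units; within the scatter), so the low end of the series is a cluster of close values rather than a single preferred configuration.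

The four compounds leave open why only compound 1 stands apart, since configuration is the only difference and it gives no mechanism. Also open, going by these compounds, is whether this dependence on configuration would persist with an amine, a carboxylic acid or a longer chain on the shared core.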